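A few compounds are considered here, and "the series" means these few. Any claim that something is new, unique, unknown or untested is made for them only; others in the source may bear on it.

Measured in a functional assay on MCF7 cells (Homo sapiens) for inhibition, read by CCK-8 assay, with a stated time of 48 h; on this read-out lower numbers stand for stronger inhibition and higher numbers for weaker inhibition:
- compound 1 `COc1cc(-c2ccnc3cc(-c4ccc(Cl)cc4)nn23)cc(OC)c1OC`: 2320 nM
- compound 2 `COc1cc(-c2ccnc3cc(-c4cccc(C#N)c4)nn23)cc(OC)c1OC`: > 10000 nM, a limit of the assay and not a number
- compound 3 `COc1cc(-c2ccnc3cc(-c4ccccc4)nn23)cc(OC)c1OC`: 254 nM

Among the measured compounds shown here, compound 3 has the lowest number of the series so far, and compound 1 is its nearest neighbour among the true numbers. The next change leads to compound 4 `COc1cc(-c2ccnc3cc(-c4ccc5c(ccn5C)c4)nn23)cc(OC)c1OC`: 1-methyl-1H-indol-5-yl in place of phenyl on an aromatic carbon.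

For the measured compounds named here, two measured steps bear on this change: a 9.1-fold lower number from compound 1 to compound 3 (0.96 log units; beyond the scatter) and an at least 39-fold lower number from compound 2 to compound 3 (1.59 log units; beyond the scatter). Going by the values given here, both end at the unsubstituted phenyl of compound 3, and no compound here goes against that direction. However, both steps concern a single substituent on a phenyl, and neither involves a 1-methyl-1H-indol-5-yl group, so they offer only a loose guide. No step beyond the scatter is therefore expected in this assay, with wide uncertainty in both directions. The expected change is a 1.3-fold lower number from compound 3 to compound 4 (0.10 log units; within the scatter). For compound 4 the estimated value is 200 nM, with an expected range of 20 nM to 3000 nM.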

Compound 4, half-maximal inhibitory concentration: 3 nM
Beside the measured number, compound 4's estimate is 67-fold (1.82 log units) above it; the whole stated range lies above it.
By their numbers in this assay, from the lowest: compound 4; then compound 3; then compound 1. At a limit, above all of these: compound 2.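

In this assay, among the compounds shown here, the earlier compounds linked changes at this aromatic carbon only with higher numbers, as chloro and cyano on the phenyl both gave weaker inhibition than the unsubstituted ring, but 1-methyl-1H-indol-5-yl reverses that direction, with an 85-fold lower number from compound 3 to compound 4 (1.93 log units; beyond the scatter). The same group also gives a 770-fold lower number from compound 1 to compound 4 (2.89 log units; beyond the scatter), so an aryl group larger than phenyl, here 10 heavy atoms in place of 6, is compatible with strong inhibition at this position. Compound 2 gives a limit and not a number, so an at least 3300-fold lower number from compound 2 to compound 4 (3.52 log units; beyond the scatter) is only a bound: the limit of > 10000 nM in this assay, at which 1 of the 4 values shown sits.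

The compounds shown do not separate the contributions of the ring nitrogen, its methyl and the fused ring. A 1H-indol-5-yl with a free ring nitrogen or a 2-naphthyl group at this position would address that question.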